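A few compounds are considered here, and "the series" means these few. Any claim that something is new, unique, unknown or untested is made for them only; others in the source may bear on it.

Working notes on the series in a functional assay on MIA PaCa-2 cells (Homo sapiens) for cytotoxicity, read by MTT assay, with a stated time of 72 h; a lower number here means a stronger inhibitor, a higher number a weaker inhibitor. Compound 1 `CCc1ccc(-c2ccc(NC3=CC(=O)c4ncncc4C3=O)cc2)cc1` gives 2000 nM; compound 2 `O=C1C(Nc2ccc(Oc3ccccc3)cc2)=CC(=O)c2ncncc21` gives 3700 nM; compound 3 `O=C1C(Nc2ccc(-c3ccc(F)cc3)cc2)=CC(=O)c2ncncc21` gives 3500 nM. Compound 3 lies inside the scatter of both others: a 1.1-fold lower number from compound 2 to compound 3 (0.02 log units; within the scatter), and a 1.8-fold higher number from compound 1 to compound 3 (0.24 log units; within the scatter); the remaining step, a 1.9-fold higher number from compound 1 to compound 2 (0.27 log units; within the scatter), is also within it, so the three numbers are indistinguishable. Compound 4 `COc1ccc(NC2=CC(=O)c3ncncc3C2=O)cc1` follows from compound 3 by methoxy in place of 4-fluorophenyl on an aromatic carbon. All three measured steps sit on the same aromatic carbon and each exchanged one ring-bearing group for another without moving the number beyond the scatter; none removed the ring as here, so the bearing is indirect. Compound 4 is therefore expected to stay within the scatter of compound 3, with the step estimated at a 1.3-fold higher number from compound 3 to compound 4 (0.11 log units; within the scatter) and a value of 4500 nM expected, between 1500 nM and 14000 nM.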

Compound 4, half-maximal inhibitory concentration: 1900 nM
Compound 4: the middle estimate sits 2.4-fold (0.37 log units) above what was measured; the range from low to high includes it.
By their numbers in this assay, from the lowest: compounds 4, 1, 3 and 2 (each within the scatter of the next).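

In this assay, for the compounds shown here, the aromatic ring at this position is lost for the first time, and all three steps remain within the scatter: a 1.8-fold lower number from compound 3 to compound 4 (0.27 log units; within the scatter), a 1.9-fold lower number from compound 2 to compound 4 (0.29 log units; within the scatter) and a 1.1-fold lower number from compound 1 to compound 4 (0.02 log units; within the scatter). At this aromatic carbon, methoxy therefore cannot be told apart from 4-fluorophenyl, 4-ethylphenyl or phenoxy, so the outer ring is not needed to retain the cytotoxicity seen in this series. No evidence is available to explain this result. As far as these compounds go, whether an amine or a carboxylic acid here would move the number beyond the scatter remains open.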